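This account rests on a few compounds, and the source may have more. Where it says the series, first, only, none or still open, it means among the compounds named here.

The study turned on a set of prenylated flavanones tested in an ADME assay on BJ cells (Homo sapiens) for cytotoxicity, with a stated time of 72 h; on this read-out lower numbers stand for an effect already at smaller amounts and higher numbers for an effect only at larger amounts of compound. Among the compounds with values here, compound 1 `CC(C)=CCC/C(C)=C/Cc1c(O)cc2c(c1O)C(=O)C[C@@H](c1cc(O)cc(O)c1)O2` gave 7500 nM, the only value in the group reported as a number. Compound 2 `C=C(C)C(O)CC/C(C)=C/Cc1c(O)cc2c(c1O)C(=O)C[C@@H](c1ccc(O)c(OC)c1)O2` reached only the limit of the assay, > 10000 nM. Compound 3 `COc1cc(O)c([C@@H]2CC(=O)c3c(O)cc(O)cc3O2)cc1C/C=C(\C)CCC=C(C)C` likewise stopped at the limit, > 10000 nM. So compound 1 stood alone as a measured quantity, against (the limit of > 10000 nM in this assay, at which 2 of the 3 values shown sit), and no single-change comparison between measured compounds was available to set the size of any step.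

Compound 4 `COc1cc([C@@H]2CC(=O)c3c(cc(O)c(C/C=C(\C)CCC=C(C)C)c3O)O2)cc(O)c1O` had not yet been measured in this assay. Against compound 1 it differed in one place: 3,4-dihydroxy-5-methoxyphenyl in place of 3,5-dihydroxyphenyl on a saturated ring carbon. Within the data shown here, with no measured step of this kind to draw on, the expectation for compound 4 could rest only on the values shown, which cluster at or near the limit. The step was therefore expected to be small, not beyond the scatter, and to fall as a 1.2-fold higher number from compound 1 to compound 4 (0.08 log units; within the scatter). Compound 4 was estimated at 9000 nM, within a range from 4000 nM to 20000 nM, with a fair chance that the assay would again report only its limit.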

Compound 4, half-maximal effective concentration: 4700 nM
Compound 4: the middle estimate sits 1.9-fold (0.28 log units) above what was measured; low and high end bracket the measured number.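

In this assay, the change on the saturated ring carbon next to the ring oxygen gives a 1.6-fold lower number from compound 1 to compound 4 (0.20 log units; within the scatter). Within the data shown here, this is the first step that can be read at this position, and it shows that exchanging 3,5-dihydroxyphenyl for 3,4-dihydroxy-5-methoxyphenyl leaves the number within the usual scatter, even though the entering group is the larger of the two. Compound 4 also gives the set a second value that is an actual number, where the earlier compounds offered only one beside their limits: the limit of > 10000 nM in this assay, at which 2 of the 4 values shown sit.

The compounds shown leave open whether a phenyl group carrying an amine or a carboxylic acid at this position would move the number beyond the scatter. They also leave open whether a change of this kind would have the same size on a core with a longer chain.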